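From fluoro to chloro on an aromatic carbon

A few compounds are considered here, and "the series" means these few. Any claim that something is new, unique, unknown or untested is made for them only; others in the source may bear on it.

Compound 1 `CC(=O)Nc1cc(-c2ccc(OC[C@@H](N)CC(C)C)c(F)c2)ccn1` is the reference point here. In an ADME assay on microsomes from liver (Mus musculus) for metabolic stability, read by LC-MS, using NADPH, with a stated time of 10 min, tested at 0.5 uM (a higher number here means that more of the compound is left, a lower number that less of the compound is left), compound 1 gives 79%. Two further compounds share its core. Compound 2 `CC(=O)Nc1cc(-c2ccc(OC[C@@](C)(N)CC(C)C)c(F)c2)ccn1` gives 70% in this assay, and compound 3 `CC(=O)Nc1cc(-c2cc(F)c(OC[C@@H](N)CC(C)C)cc2F)ccn1` gives 70%. The number for compound 1 is the largest of the three, yet the two steps away from it, a number 9 percentage points lower from compound 1 to compound 2 (within the scatter) and a number 9 percentage points lower from compound 1 to compound 3 (within the scatter), are both within the scatter, so the three compounds cannot really be told apart on this read-out.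

Compound 4 `CC(=O)Nc1cc(-c2ccc(OC[C@@H](N)CC(C)C)c(Cl)c2)ccn1` has not yet been measured. It differs from compound 1 in one place: chloro in place of fluoro on an aromatic carbon. Within the data shown here, the only measured step that touches the same kind of position is the one to compound 3, where a fluoro replaced a hydrogen on an aromatic carbon and the result, a number 9 percentage points lower from compound 1 to compound 3 (within the scatter), stayed within the scatter. Exchanging one halogen for another at an aromatic carbon is a smaller change than adding one, so no movement beyond the scatter is expected in this assay, with perhaps a slight drift downward in line with the step to compound 3.

For compound 4 the step of a number 7 percentage points lower from compound 1 to compound 4 (within the scatter) is therefore expected to be small. The estimate for compound 4 is 72%, with a range from 55% to 88%.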

Compound 4, percent of the compound remaining: 86%
Estimate against measurement, compound 4: 14 percentage points below, within the range that was stated.
By their numbers in this assay, from the lowest: compounds 2, 3, 1 and 4 (each within the scatter of the next, the first and the last beyond it).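

Compound 1, compound 2 and compound 3 all carry fluoro on the aromatic carbon ortho to the (2-amino-4-methylpentyl)oxy group, so they say nothing about a different group at that carbon. Chloro in place of fluoro there gives a number 7 percentage points higher from compound 1 to compound 4 (within the scatter) in this assay, which means that this carbon can carry either halogen without a difference that this read-out can separate from the ordinary spread of repeated measurements. No measurement shown here offers an explanation for the result at this carbon.

On these data alone, it remains open whether a group other than a halogen on this carbon, such as a methyl, a methoxy or a nitrile, would shift the percentage of compound remaining beyond that spread, and what plain hydrogen there would give. Among these compounds, also open is whether chloro would give a similar reading when combined with the 1-amino-1,3-dimethylbutyl chain of compound 2 or with the second fluoro of compound 3, since each of those changes has so far been seen only with fluoro on this carbon.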